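Iodo for ethynyl on a shared core: a second instance

The compounds below may be only part of what the source reports. "The series", "measured", "known", "first", "only" and "open" are said of these compounds alone.

Measured compounds:
Compound 1, `Cc1ncnc2c1c(I)cn2[C@@H]1O[C@H](CO)[C@@H](O)[C@H]1O`: 12200 nM
Compound 2, `C#Cc1cn([C@@H]2O[C@H](CO)[C@@H](O)[C@H]2O)c2ncnc(C)c12`: 19200 nM
Compound 3, `C#Cc1cn([C@@H]2O[C@H](CO)[C@@H](O)[C@H]2O)c2nc(C)nc(N)c12`: > 20000 nM

The account concerns three measured compounds and one that is not yet measured, compound 4, `Cc1nc(N)c2c(I)cn([C@@H]3O[C@H](CO)[C@@H](O)[C@H]3O)c2n1`. All are judged in a functional assay on A549 cells (Homo sapiens), read by MTT assay, with a stated time of 72 h; a higher number here means a weaker inhibitor, a lower number a stronger inhibitor. Compound 2 gives 19200 nM there, and compound 1 gives 12200 nM. The change between them, (iodo in place of ethynyl on an aromatic carbon), made a step of a 1.6-fold lower number from compound 2 to compound 1 (0.20 log units; within the scatter), so the two values cannot be told apart.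

For compound 3 the outcome in this assay is a limit of the assay and not a number, > 20000 nM. This rests on (the limit of > 20000 nM in this assay, at which 1 of the 3 values shown sits).

Compound 4 is related to compound 3 by the same change, (iodo in place of ethynyl on an aromatic carbon), and the two place lines read the same word for word. The difference between the core of compound 3 and the core of compound 2 is not broken down here.

Because the earlier step of a 1.6-fold lower number from compound 2 to compound 1 (0.20 log units; within the scatter) lay within the scatter, the same change is expected to move compound 4 little from compound 3, so that for compound 4 the expected step is a step that the limit leaves unreadable from compound 3 to compound 4. Since compound 3 gave only a limit, it is expected that compound 4 will most likely also give a limit in this assay, and its estimated value is 25000 nM, expected between 10000 nM and 80000 nM.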

Compound 4, half-maximal inhibitory concentration: 12100 nM
Compound 4: the middle estimate sits 2.1-fold (0.32 log units) above what was measured, and the stated range covers the measured number.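

On the core of compound 3, iodo in place of ethynyl on an aromatic carbon gave an at least 1.6-fold lower number from compound 3 to compound 4 (0.21 log units; that floor lies within the scatter) in this assay. Compound 3 stands at > 20000 nM, which is a limit of the assay and not a number, so the full size of this step cannot be read. The result shows that the change can be set beside the earlier step only as far as this floor allows, and it does not show that the change carries from one core to the other with the same size: the same change on two cores in this assay, a 1.6-fold lower number (0.20 log units; within the scatter) from compound 2 to compound 1 and an at least 1.6-fold lower number (0.21 log units; that floor lies within the scatter) from compound 3 to compound 4; the limit leaves it open whether they differ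

The compounds shown leave open how other groups on this aromatic carbon of the five-membered ring, such as bromo, a nitrile or an aminomethyl group, would read in this assay, since ethynyl and iodo are the only two groups seen there. They also leave open what the difference between the core of compound 2 and the core of compound 3 does by itself, and whether the change would behave in the same way on any core beyond these two.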